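The compounds below may be only part of what the source reports. "The series", "measured", "known", "first", "only" and "open" are said of these compounds alone.

Of the compounds shown here, two have been measured so far. Compound 1 `COc1ccc(-c2cc3nccc(-c4cc(OC)c(OC)c(OC)c4)n3n2)cc1N` was tested in a functional assay on A549 cells (Homo sapiens) for inhibition, read by CCK-8 assay, with a stated time of 48 h (a higher number here means a weaker inhibitor, a lower number a stronger inhibitor), where compound 1 gives 138 nM. Compound 2 `Cn1ccc2cc(-c3cc4nccc(-c5ccc(F)cc5)n4n3)ccc21` carries a different pair of aromatic groups on the shared core, and in this assay compound 2 gives 3520 nM. Of these two numbers, compound 1 has the lower one, and the gap between compound 1 and compound 2 lies well beyond the usual scatter of such measurements, so compound 1 is the stronger inhibitor of the pair.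

The next compound, compound 3 `COc1cc(-c2ccnc3cc(-c4ccc(N(C)C)cc4)nn23)cc(OC)c1OC`, keeps the core of compound 1 and its trimethoxyphenyl group and changes only one of the two aromatic substituents: 4-(dimethylamino)phenyl in place of 3-amino-4-methoxyphenyl on an aromatic carbon. Going by the values given here, no measured pair yet shows what this particular swap does, so any expectation rests on compound 1 alone. A step upward from compound 1 to compound 3, that is toward weaker inhibition, is expected, of a size a 3.6-fold higher number from compound 1 to compound 3 (0.56 log units; beyond the scatter). Compound 3 is accordingly estimated at 500 nM, with a plausible range from 150 nM to 2000 nM.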

Compound 3, half-maximal inhibitory concentration: 1100 nM
For compound 3 the middle estimate is 2.2-fold (0.34 log units) below the measured one; the range from low to high includes it.
By their numbers in this assay, from the lowest: compound 1; then compound 3; then compound 2.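

In this assay, putting 4-(dimethylamino)phenyl in place of 3-amino-4-methoxyphenyl on this aromatic carbon gives an 8.0-fold higher number from compound 1 to compound 3 (0.90 log units; beyond the scatter), a weakening of inhibition beyond the usual scatter. Going by these compounds alone, this is the first direct reading at this position, and it shows that the group held there matters even with the trimethoxyphenyl group and the shared core unchanged. The two groups match in having one six-membered aromatic ring of carbon only and 9 heavy atoms, while the entering group counts 0 hydrogen-bond donors and 1 acceptor against 1 donor and 2 acceptors for the leaving group, but nothing measured here explains the loss of inhibition.

This single step changes the amino group and the methoxy group together, so the compounds shown cannot say which of the two carries the difference, or whether the dimethylamino group itself is what weakens inhibition. A 3-hydroxy-4-methoxyphenyl group, a 4-methoxyphenyl group or a plain phenyl group at this position would each be a narrower test of the same question.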